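The compounds below may be only part of what the source reports. "The series", "measured", "known", "first", "only" and "open" are said of these compounds alone.

In a functional assay on A549 cells (Homo sapiens) for antiproliferative activity, read by MTT assay, with a stated time of 48 h (on this read-out higher numbers stand for weaker inhibition and lower numbers for stronger inhibition), compound 1 (`COc1ccc(C(=O)c2ccc(OC)c3c2C=CC(C)(C)O3)c(NC(=O)CBr)c1`) gives 2460 nM while compound 2 (`COc1ccc(C(=O)c2ccc(OC)c3c2C=CC(C)(C)O3)c(NC(=O)CO)c1`) gives 100 nM and compound 3 (`COc1ccc(C(=O)c2cc(OC)c(OC)c(OC)c2)c(NC(=O)CO)c1`) gives 70 nM on a different core. Compound 3 thus stands level with compound 2 within the scatter and well under compound 1. Compound 4 (`CCNCC(=O)Nc1cc(OC)ccc1C(=O)c1cc(OC)c(OC)c(OC)c1`) keeps the core of compound 3 and changes one group (ethylamino in place of hydroxy on a saturated chain carbon bound to a carbonyl carbon): ethylamino in place of hydroxy on a saturated chain carbon bound to a carbonyl carbon. Among the measured compounds shown here, only one measured step touches this place (a 25-fold lower number from compound 1 to compound 2 (1.39 log units; beyond the scatter)), where hydroxy replaces bromo on the core of compound 1. For the measured compounds named here, that step is large, so the group here can matter, but no compound with ethylamino has been measured and the step comes from another core. Since the two hydroxy compounds both sit low, leaving hydroxy is expected to raise the number, though by much less than that step. The expected change is a 2.9-fold higher number from compound 3 to compound 4 (0.46 log units; beyond the scatter) and could stay close to the scatter. For compound 4 the estimated value is 200 nM (expected range 50 nM to 800 nM).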

Compound 4, half-maximal inhibitory concentration: 750 nM
Estimate against measurement, compound 4: 3.8-fold (0.57 log units) below, and the stated range covers the measured number.
By their numbers in this assay, from the lowest: compounds 3 and 2 (each within the scatter of the next); then compound 4; then compound 1.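

In this assay, the group at this place also counts on the core of compound 3, not only on the core of compound 1: an 11-fold higher number from compound 3 to compound 4 (1.03 log units; beyond the scatter) is large and lies beyond the scatter. Among the compounds shown here, until now, the only step here had been bromo to hydroxy, so this is the first measured case of hydroxy being replaced with a loss of inhibition, and it happens although hydroxy and ethylamino show the same counts of hydrogen-bond donors and acceptors and no net charge. No measurement at hand gives a reason for this step.

The compounds shown leave open whether amino, methylamino or dimethylamino on the saturated chain carbon bound to a carbonyl carbon would fall closer to hydroxy or to ethylamino. They also leave open whether ethylamino would give a similar step on the core of compound 1.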